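A few compounds are considered here, and "the series" means these few. Any claim that something is new, unique, unknown or untested is made for them only; others in the source may bear on it.

The measured compounds:

- compound 1 `C=C(Br)C(=O)Nc1cccc(-c2cn3nc(-c4ccccc4)sc3n2)c1`, in a functional assay on HeLa cells (Homo sapiens) for inhibition, read by cell counting, with a stated time of 4 days (on this read-out higher numbers stand for weaker inhibition and lower numbers for stronger inhibition), compound 1 gives 1400 nM
- compound 3 `COc1ccc(-c2csc3nc(-c4cccc(N)c4)cn23)cc1`, in this assay compound 3 gives 19000 nM
- compound 2 `COc1ccc(-c2nn3cc(-c4cccc(N)c4)nc3s2)cc1`, for which this assay reports only a limit, >= 250000 nM

Compound 1 stands at the lowest of the two numbers shown. Compound 3 sits at a higher number, and the gap between compound 1 and compound 3 lies beyond the scatter of this assay. The value of compound 2 is a limit of the assay and not a number, as noted in the limit of >= 250000 nM in this assay, at which 1 of the 3 values shown sits.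

Compound 4 `C=C(Br)C(=O)Nc1cccc(-c2cn3nc(CCc4ccccc4)sc3n2)c1` is not yet measured. It differs from compound 1 in one place: phenethyl in place of phenyl on an aromatic carbon. Going by the values given here, no pair of measured compounds shares this kind of change, so no measured step sets its size. Compound 4 is expected to give a number of the same order as compound 1, with the step of a 2.1-fold higher number from compound 1 to compound 4 (0.33 log units; beyond the scatter) estimated at no more than a modest loss, possibly within the scatter. The estimate for compound 4 in this assay is 3000 nM, ranging from 800 nM to 12000 nM.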

Compound 4, half-maximal inhibitory concentration: 3300 nM
The estimate for compound 4 lay 1.1-fold (0.04 log units) below the measured number, within the range that was stated.
By their numbers in this assay, from the lowest: compound 1; then compound 4; then compound 3. At a limit, above all of these: compound 2.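

In this assay, going by these compounds alone, the change of phenyl to phenethyl gives a 2.4-fold higher number from compound 1 to compound 4 (0.37 log units; beyond the scatter) and so sets the first size of a step at this aromatic carbon, where the earlier compounds held none. The step is modest, so in this one pair the position tolerates phenethyl, although phenethyl does not improve on phenyl. The compounds shown offer no measured property that would explain this step.

From the compounds shown here alone, what an amine, a carboxylic acid or a chain longer than phenethyl would give at this position stays open. Going by these compounds, it also stays open whether the same change of phenyl to phenethyl would give a step of similar size on another core, since this single pair cannot show how far the result carries.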